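This account rests on a few compounds, and the source may have more. Where it says the series, first, only, none or still open, it means among the compounds named here.

Measured compounds in the series:

Compound 1, `COc1ccc2c(=O)c(/C=C/C(=O)Nc3ccccc3)coc2c1`. In a functional assay on L02 cells (Homo sapiens) for inhibition, read by MTT assay, with a stated time of 48 h (on this read-out higher numbers stand for weaker inhibition and lower numbers for stronger inhibition), compound 1 gives > 200000 nM, which is a limit of the assay and not a number.
Compound 2, `COc1ccc2c(=O)c(/C=C/C(=O)NCc3ccc(C)cc3)coc2c1`. In this assay compound 2 gives > 200000 nM, again a limit.
Compound 3, `Cc1ccc(CNC(=O)/C=C/c2coc3cc(O)ccc3c2=O)cc1`. In this assay compound 3 gives > 200000 nM, likewise a limit.

Going by the values given here, all three measured values sit at the same place, (the limit of > 200000 nM in this assay, at which 3 of the 3 values shown sit), so none of the measured steps can be read in size. The change phenyl in place of 4-methylbenzyl on an amide-type nitrogen gives a step that the two limits leave unreadable from compound 2 to compound 1. The change in the core, (hydrogen in place of methyl on an oxygen on an aromatic ring), gives a step that the two limits leave unreadable from compound 2 to compound 3. Neither step is readable, and no ordering among compound 1, compound 2 and compound 3 can be claimed.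

Compound 4, `O=C(/C=C/c1coc2cc(O)ccc2c1=O)Nc1ccccc1`, has not been measured in this assay. It differs from compound 3 by phenyl in place of 4-methylbenzyl on an amide-type nitrogen, the same change that leads from compound 2 to compound 1; the place is described in the same words in both cases. Since that earlier step was a step that the two limits leave unreadable from compound 2 to compound 1 and its starting point already sat at the limit, the step from compound 3 to compound 4 is expected to be a step that the limit leaves unreadable from compound 3 to compound 4, resting only on the fact that every measured value in this assay is a limit, (the limit of > 200000 nM in this assay, at which 3 of the 3 values shown sit).

The value of compound 4 in this assay is expected to be 300000 nM, with a likely span from 100000 nM to 2000000 nM, and most probably the assay will again report only a limit for compound 4.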

Compound 4, half-maximal inhibitory concentration: > 200000 nM
Compound 4 was reported as a limit (the forecaster's own chance of this, stated with the estimate: 85%); the middle value does not contradict the limit.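

Compound 4 gives > 200000 nM in this assay, which is a limit of the assay and not a number, so its steps from compound 3 and compound 1 cannot be read in size: the limit of > 200000 nM in this assay, at which 4 of the 4 values shown sit.

The compounds shown leave open whether phenyl or 4-methylbenzyl on the amide-type nitrogen, or hydrogen or methyl on the oxygen, makes any difference to the read-out.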